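Working notes: methyl in place of chloro

A few compounds are considered here, and "the series" means these few. Any claim that something is new, unique, unknown or untested is made for them only; others in the source may bear on it.

Measured in an ADME assay on a cell-free system (plasma, Homo sapiens); on this read-out lower numbers stand for a smaller free fraction and higher numbers for a larger free fraction:
- compound 1 `Cc1ccc(S(=O)(=O)N(C)C(C)C)cc1C#Cc1cc(Cl)ccc1OCC(=O)O`: 0.002
- compound 2 `COCCNS(=O)(=O)c1ccc(C)c(C#Cc2cc(Cl)ccc2OCC(=O)O)c1`: "not determined" (no result reported)
- compound 3 `CS(=O)(=O)c1ccc(Cl)c(C#Cc2cc(Cl)ccc2OCC(=O)O)c1`: 0.007

Only two of these compounds have a number. Compound 3 at 0.007 holds the higher one, and compound 1 at 0.002 lies lower, a gap beyond the usual scatter. These two compounds differ in more than one place, so the gap does not size any single change.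

The next compound to read is compound 4 `Cc1ccc(S(C)(=O)=O)cc1C#Cc1cc(Cl)ccc1OCC(=O)O`, not yet measured. Relative to compound 3, it carries methyl in place of chloro on an aromatic carbon, ortho to a large group and para to a methylsulfonyl group: methyl in place of chloro on an aromatic carbon. Among the measured compounds shown here, no measured pair isolates this change, so the expectation rests on compound 3 alone. In this assay, no shift beyond the scatter is expected, and no direction is favoured with any confidence. The expected step is a 1.2-fold lower number from compound 3 to compound 4 (0.07 log units; within the scatter). Compound 4 is estimated at 0.006, with an expected range from 0.003 to 0.012.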

Compound 4, unbound fraction: 0.017
Compound 4: middle estimate off by 2.8-fold (0.45 log units), on the low side; measured number above the stated range.
By their numbers in this assay, from the lowest: compound 1; then compound 3; then compound 4.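

In this assay, among the compounds shown here, methyl in place of chloro on an aromatic carbon, ortho to a large group and para to a methylsulfonyl group, gives a 2.4-fold higher number from compound 3 to compound 4 (0.39 log units; beyond the scatter) and is the first measured single change at this place, showing that the free fraction responds to it beyond the scatter. Methyl in place of isopropyl(methyl)amino on a sulfonyl sulfur gives an 8.5-fold higher number from compound 1 to compound 4 (0.93 log units; beyond the scatter) and shows a second place where a single change moves the read-out, again towards a larger free fraction. The data at hand give no cause for either step.

On these data alone, whether other groups on the same aromatic carbon, such as fluoro or a nitrile, would shift the free fraction remains open. Also open, as far as these compounds go, is whether the step from chloro to methyl keeps its size and direction when the sulfonyl sulfur carries isopropyl(methyl)amino or an amine with a longer chain.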